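The source may hold more compounds than are shown below. What is called first, only, known or untested is meant among the compounds shown, and "the series" means these compounds.

Measured in a functional assay on MES-SA cells (Homo sapiens) for inhibition, with a stated time of 72 h; on this read-out lower numbers stand for stronger inhibition and higher numbers for weaker inhibition:
- compound 1 `Oc1c(CN2CCCCC2)ccc2cccnc12`: 5210 nM; 5130 nM (2 entries)
- compound 2 `COCc1cc(CN2CCCC2)c(O)c2ncccc12`: 11000 nM

The repeat entries for compound 1 agree closely: the several entries of compound 1 in this assay, 5210 nM; 5130 nM (2 entries). Compound 2 rests on one number, 11000 nM, the higher of the two compounds' values, and one further entry for it gives no single number.

Compound 3 `COCc1cc(CN2CCCCC2)c(O)c2ncccc12` departs from compound 2 by one change: piperidin-1-yl in place of pyrrolidin-1-yl on a saturated chain carbon bound to an aromatic carbon. Within the data shown here, no measured pair isolates this change. Compound 1 also carries piperidin-1-yl but differs from compound 2 elsewhere, so compound 1 with 5210 nM; 5130 nM (2 entries) gives only a weak hint. In this assay a small shift towards lower numbers is expected, quite possibly none beyond the scatter. The estimated step is a 1.4-fold lower number from compound 2 to compound 3 (0.14 log units; within the scatter). For compound 3 the expected value is 8000 nM, with an estimated range of 3500 nM to 18000 nM.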

Compound 3, half-maximal inhibitory concentration: 9330 nM
For compound 3 the middle estimate is 1.2-fold (0.07 log units) below the measured one; the measured number falls inside the stated range.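

Among these compounds, the first direct reading of this change at this position is a 1.2-fold lower number from compound 2 to compound 3 (0.07 log units; within the scatter), in this assay. Piperidin-1-yl and pyrrolidin-1-yl on a saturated chain carbon bound to an aromatic carbon are therefore not separated by this read-out, so the extra ring member in the (piperidin-1-yl)methyl group has no resolved effect here. Nothing available on these compounds offers a reason for this close agreement.

Going by these compounds, it remains open whether a morpholin-4-yl group or an open-chain amine such as dimethylamino at this place would move the number in this assay beyond the scatter. A single pair also cannot show whether the same ring swap would read alike on a different core, so no general rule for the series follows from it.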